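This account rests on a few compounds, and the source may have more. Where it says the series, first, only, none or still open, it means among the compounds named here.

Measured in a physicochemical assay for solubility, measured as kinetic solubility; on this read-out lower numbers stand for lower solubility and higher numbers for higher solubility:

Compound 1 `Cc1cnc(NC(=O)c2cc(Oc3cnc(C(=O)N(C)C)cn3)c3cn(C)nc3c2)cn1`: 192000 nM
Compound 2 `Cc1cnc(NC(=O)c2cc(Oc3cnc(C(=O)N(C)C)cn3)c3cc(C)nn3c2)cn1`: 123000 nM
Compound 3 `Cc1cnc(NC(=O)c2cc(Oc3ccc(C(=O)N(C)C)cc3)c3cn(C)nc3c2)cn1`: 351000 nM

Among these three, compound 3 holds the highest number at 351000 nM, though not by a clear margin over every neighbour. Its gap to compound 1 lies within the scatter, and its gap to compound 2 lies beyond the scatter.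

The next compound to be tested is compound 4 `Cc1cnc(NC(=O)c2cc(Oc3ccc(S(=O)(=O)C4CC4)cc3)c3cn(C)nc3c2)cn1`. It keeps the shared core of compound 3 and carries cyclopropylsulfonyl in place of dimethylcarbamoyl on an aromatic carbon, on a six-membered aromatic ring of carbon only, para to a large group. The counted difference reads (cyclopropylsulfonyl in place of dimethylcarbamoyl on an aromatic carbon).

Going by the values given here, no pair of measured compounds differs in one place only, so the data give no direct measure of this exchange, and any forecast is a judgement with wide margins. A move to a lower number is expected, of moderate size, starting from the top of the measured values. The expected change is a 2.3-fold lower number from compound 3 to compound 4 (0.37 log units; beyond the scatter). For compound 4 the estimated value in this assay is 150000 nM, with an expected range from 50000 nM to 350000 nM.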

Compound 4, solubility: 73000 nM
Compound 4: middle estimate off by 2.1-fold (0.31 log units), on the high side; low and high end bracket the measured number.
By their numbers in this assay, from the lowest: compounds 4, 2, 1 and 3 (each within the scatter of the next, the first and the last beyond it).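

In this assay, going by these compounds alone, putting cyclopropylsulfonyl in place of dimethylcarbamoyl, on an aromatic carbon of the six-membered aromatic ring of carbon only, para to a large group, gives the only single-place reading in this set: a 4.8-fold lower number from compound 3 to compound 4 (0.68 log units; beyond the scatter), a step beyond the scatter. This shows that the number responds to what sits at this position while the rest of the structure stays fixed, something compounds 1, 2 and 3 could not show, as none of them differs from another in one place only. Nothing measured here explains the direction or size of this step.

Going by these compounds, it remains open whether the fall belongs to the sulfonyl or to the cyclopropyl ring, which a methylsulfonyl group or a cyclopropyl amide at the same position could separate, and whether a morpholine amide or a carboxylic acid there would give a number nearer to that of compound 3 or of compound 4. On these data alone, it is also open whether the same exchange would give a step of similar size on the core of compound 1 or of compound 2.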